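Chloro for Fluoro on the Sulfonyl Ring, Tried Again

The source may report more compounds than this note shows. Statements on the series, on what has been measured and on what is new or still open speak of the compounds shown alone.

Three compounds have been measured in an assay on U2OS cells for activation of nuclear factor erythroid 2-related factor 2 (Homo sapiens), read by beta-arrestin recruitment, with a stated time of 6 h; a higher number here means that more compound is needed for the effect, a lower number that less compound is needed:
compound 1 `O=S(=O)(/C=C\c1ncccc1F)c1ccccc1F` gives 482 nM;
compound 2 `O=S(=O)(/C=C/c1ccccn1)c1cccc(F)c1` gives 1680 nM;
compound 3 `O=S(=O)(/C=C\c1ncccc1F)c1ccccc1Cl` gives 583 nM.

Compound 1 and compound 3 differ by chloro in place of fluoro on an aromatic carbon, and the step is a 1.2-fold higher number from compound 1 to compound 3 (0.08 log units; within the scatter). Compound 2 has the highest number of the three; the difference between its core and the core of compound 1 is not broken down here. Compound 4 `O=S(=O)(/C=C/c1ccccn1)c1cccc(Cl)c1` differs from compound 2 by chloro in place of fluoro on an aromatic carbon. This is the same kind of change as from compound 1 to compound 3, but the place differs: there the chloro sits ortho to a large group, here meta to a large group. Resting on the measured step of a 1.2-fold higher number from compound 1 to compound 3 (0.08 log units; within the scatter), the expected step is a 1.2-fold higher number from compound 2 to compound 4 (0.08 log units; within the scatter). Compound 4 is therefore estimated to give 2000 nM, expected to fall between 1000 nM and 4000 nM.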

Compound 4, half-maximal effective concentration: 1430 nM
Compound 4: the middle estimate sits 1.4-fold (0.15 log units) above what was measured; the range from low to high includes it.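

In this assay, chloro in place of fluoro on an aromatic carbon gives a 1.2-fold lower number from compound 2 to compound 4 (0.07 log units; within the scatter), so on this core too the change moves the number by no more than the scatter. Set beside the earlier step, the two cores show no difference in what the change does: the same change on two cores in this assay, a 1.2-fold higher number (0.08 log units; within the scatter) from compound 1 to compound 3 and a 1.2-fold lower number (0.07 log units; within the scatter) from compound 2 to compound 4, 1.4-fold (0.15 log units) apart, within the scatter of two such steps. This supports carrying the change between these two cores only; it does not show that other cores would behave alike, and neither step says why the number stays put.

Only fluoro and chloro appear at the place of the change. On these data alone, it remains open what a methoxy group, a nitrile or an amine would do there.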